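This account rests on a few compounds, and the source may have more. Where it says the series, first, only, none or still open, it means among the compounds named here.

Measured compounds in the series:

- compound 1, `OC[C@]1(c2ccc(F)cc2)NC[C@H](O)[C@H]1O`: 6.6%
- compound 2, `COc1cccc([C@]2(CO)NC[C@@H](O)[C@@H]2O)c1`: 0%

Both were run in an assay on isolated protein for inhibition of alpha-mannosidase (Canavalia ensiformis), tested at 1000 uM; a lower number here means less inhibition, a higher number more inhibition at the concentration tested (going by the name of the read-out). Compound 1 gives 6.6% and compound 2 gives 0%; the two numbers lie within the usual scatter of each other, so compound 1 does not stand apart from compound 2 on this evidence, and neither compound shows appreciable inhibition at the concentration tested. Among the measured compounds shown here, no step between two measured compounds that differ in one place is available, so no measured change of this kind anchors the series.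

Compound 3, `Cc1ccc([C@@]2(CO)NC[C@H](O)[C@H]2O)cc1`, has not been run in this assay. It differs from compound 1 by methyl in place of fluoro on an aromatic carbon. For the measured compounds named here, with both measured compounds sitting near the floor of the read-out and no measured step to go by, the expectation is for no change beyond the scatter: the step of a number 1.6 percentage points lower from compound 1 to compound 3 (within the scatter) is estimated to be small. Compound 3 is therefore expected to give about 5% in this assay, within a range from 0% to 15%.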

Compound 3, a percentage reported as inhibition, at one concentration (the size of the read-out at that concentration, not a potency): 0%
For compound 3 the middle estimate is 5 percentage points above the measured one, within the range that was stated.
By their numbers in this assay, from the lowest: compounds 2, 3 and 1 (each within the scatter of the next).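

Among the compounds shown here, the step from fluoro to methyl is the first measured change, and it sits on an aromatic carbon of a six-membered aromatic ring of carbon only, para to a group of 9 heavy atoms: in this assay it reads as a number 6.6 percentage points lower from compound 1 to compound 3 (within the scatter) and so does not separate the two compounds. With both numbers close to the floor of the read-out, this single exchange of one heavy atom for another cannot show whether this position has any bearing on inhibition at the concentration tested. No measurement at hand bears on why the two compounds read alike.

Open, going by these compounds, is whether a group of a different kind on this carbon, such as an amine or a carboxylic acid, would lift the number in this assay clear of the scatter. Also open, on these data alone, is whether a longer chain at the same place would do so, or whether the read-out stays near its floor whatever stands there.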